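Working notes: from compound 3 to compound 4

The source may report more compounds than this note shows. Statements on the series, on what has been measured and on what is new or still open speak of the compounds shown alone.

Measured in a functional assay on HepG2 cells (Homo sapiens) for antiproliferative activity, read by MTT assay, with a stated time of 48 h; on this read-out higher numbers stand for weaker inhibition and lower numbers for stronger inhibition:
- compound 1 `CC(=O)N1N=C(c2ccc3ccccc3c2)OC1c1ccccc1`: 2.11 ug/mL
- compound 2 `CC(=O)N1N=C(c2ccc3ccccc3c2)OC1c1ccc(Br)cc1`: 2.08 ug/mL
- compound 3 `CC(=O)N1N=C(c2ccc3ccccc3c2)OC1c1cccc(F)c1`: 1.86 ug/mL

Compound 3 lies within the scatter of both other compounds, so the three form one level group and no order can be read among them.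

The next compound is compound 4 `CC(=O)N1N=C(c2ccc3ccccc3c2)OC1c1ccc([N+](=O)[O-])cc1`. The change is 4-nitrophenyl in place of 3-fluorophenyl on a saturated ring carbon, in words 4-nitrophenyl in place of 3-fluorophenyl on a saturated ring carbon.

Three measured steps change the aryl group at this same carbon: a 1.0-fold lower number from compound 1 to compound 2 (0.01 log units; within the scatter), a 1.1-fold lower number from compound 1 to compound 3 (0.05 log units; within the scatter) and a 1.1-fold lower number from compound 2 to compound 3 (0.05 log units; within the scatter). All three stay within the scatter. None of them involves a nitro group, so the series offers only indirect guidance and the range is kept wide.

No step beyond the scatter is therefore expected in this assay, and the estimate is a 1.1-fold higher number from compound 3 to compound 4 (0.03 log units; within the scatter) as the expected step. Compound 4 is expected at 2 ug/mL with 1.2 ug/mL to 3.4 ug/mL as the estimated range.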

Compound 4, half-maximal inhibitory concentration: 8.1 ug/mL
Beside the measured number, compound 4's estimate is 4.1-fold (0.61 log units) below it, outside the stated range (above it).
By their numbers in this assay, from the lowest: compounds 3, 2 and 1 (each within the scatter of the next); then compound 4.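

The aryl group on this saturated ring carbon is not indifferent in this assay: nitro in place of hydrogen gives a 3.8-fold higher number from compound 1 to compound 4 (0.58 log units; beyond the scatter), whereas the earlier aryl changes all stayed within the scatter. Nitro in place of bromo on the same aromatic carbon gives a 3.9-fold higher number from compound 2 to compound 4 (0.59 log units; beyond the scatter), so among compounds 1, 2 and 4 a substituent there does not by itself shift the number, and the full aryl exchange gives a step of similar size with a 4.4-fold higher number from compound 3 to compound 4 (0.64 log units; beyond the scatter). Nothing measured here bears on the cause of this shift.

Going by these compounds alone, with only one nitro compound, a single result carries this finding, and whether it is specific to nitro stays open. How an amine, a nitrile or a carboxylic acid on this phenyl ring would read in this assay cannot be told from the compounds shown.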